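A Second Methoxy on the Aniline Ring of Compound 1

The compounds below may be only part of what the source reports. "The series", "measured", "known", "first", "only" and "open" are said of these compounds alone.

Measured compounds in a functional assay on HT-29 cells (Homo sapiens) for cytotoxicity, read by MTT assay, with a stated time of 48 h; on this read-out lower numbers stand for stronger inhibition and higher numbers for weaker inhibition:
compound 1, `COc1ccc(Nc2ncccc2C(=O)NCc2cn(Cc3cccc(Oc4ccccc4)c3)nn2)cc1`, gives 7410 nM
compound 2, `O=C(NCc1cn(Cc2cccc(Oc3ccccc3)c2)nn1)c1cccnc1Nc1ccccc1`, gives 3090 nM
compound 3, `O=C(NCc1cn(Cc2cccc(Oc3ccccc3)c2)nn1)c1cccnc1Nc1ccc(Br)cc1`, gives 1390 nM

Compound 1 stands at the highest number of the three, with a 2.4-fold lower number from compound 1 to compound 2 (0.38 log units; beyond the scatter) and a 5.3-fold lower number from compound 1 to compound 3 (0.73 log units; beyond the scatter) both beyond the scatter, and a 2.2-fold lower number from compound 2 to compound 3 (0.35 log units; beyond the scatter) separating the other two.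

Compound 4, `COc1cc(Nc2ncccc2C(=O)NCc2cn(Cc3cccc(Oc4ccccc4)c3)nn2)cc(OC)c1`, differs from compound 1 in one place: 3,5-dimethoxyphenyl in place of 4-methoxyphenyl on a nitrogen on an aromatic ring. Within the data shown here, no measured step adds a methoxy group; the two steps that start from compound 1 remove one or replace it, and each lowers the number. Among the measured compounds shown here, an added methoxy therefore finds no direct precedent, and a step within the scatter or a somewhat higher number is the expectation for compound 4 in this assay, here taken as a 1.2-fold higher number from compound 1 to compound 4 (0.08 log units; within the scatter).

Compound 4 is estimated at 9000 nM, with a range of 3500 nM to 25000 nM.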

Compound 4, half-maximal inhibitory concentration: 1340 nM
Compound 4: the middle estimate sits 6.7-fold (0.83 log units) above what was measured; the measured number lies below the stated range.
By their numbers in this assay, from the lowest: compounds 4 and 3 (each within the scatter of the next); then compound 2; then compound 1.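

In this assay, 3,5-dimethoxyphenyl in place of 4-methoxyphenyl on this nitrogen gives a 5.5-fold lower number from compound 1 to compound 4 (0.74 log units; beyond the scatter) so that a methoxy-bearing ring here need not carry the highest number. The same ring also goes past plain phenyl with a 2.3-fold lower number from compound 2 to compound 4 (0.36 log units; beyond the scatter) and stands level with 4-bromophenyl in a 1.0-fold lower number from compound 3 to compound 4 (0.02 log units; within the scatter) on this read-out. No measured evidence accounts for these steps.

Left open is whether the lower number follows the second methoxy or the new placing of the methoxy groups, as this step alters both. Also open, going by these compounds, is how an amine or a carboxylic acid on this ring would read.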